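The source may report more compounds than this note shows. Statements on the series, on what has been measured and on what is new or still open speak of the compounds shown alone.

Of the compounds shown here, two have so far been measured in an ADME assay on MCF7 cells (Homo sapiens) for cytotoxicity, read by MTT assay, with a stated time of 48 h; a lower number here means a stronger inhibitor, a higher number a weaker inhibitor. Compound 1 `Clc1ccc(-c2csnn2)cc1` reaches only the limit of this assay: compound 1 gives > 100000 nM, a limit rather than a number. Compound 2 `C/C(=N\NC(=O)COc1cccc2cccnc12)c1ccc(Cl)cc1` likewise reaches only a limit, and in this assay compound 2 gives > 100000 nM. On the numbers shown, compound 2 therefore stands at the limit of > 100000 nM in this assay, at which 2 of the 2 values shown sit, and no figure separates it from compound 1.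

Compound 3 `C/C(=N\NC(=O)COc1cccc2cccnc12)c1ccccn1` has not yet been measured. It differs from compound 2 in one place: pyridin-2-yl in place of 4-chlorophenyl on a carbon with a double bond to nitrogen. Among the compounds with values here, no step between measured compounds is known here, so the size of this change can only be expected. The step of a number no higher from compound 2 to compound 3 (the limit leaves the size open) is expected to be none beyond the scatter. Compound 3 is thus expected to give about 100000 nM, between 20000 nM and 500000 nM, and it may once more return only a limit.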

Compound 3, half-maximal inhibitory concentration: > 100000 nM
Compound 3 ended at the assay's limit (the forecaster's own chance of this, stated with the estimate: 70%); the middle value sits exactly at the limit.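

In this assay, within the data shown here, compound 3 gives > 100000 nM, again a limit and not a number, so no step from compound 2 to compound 3 can be read. The compounds shown leave open how far each lies past that limit, and whether pyridin-2-yl and 4-chlorophenyl differ at all here.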